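A few compounds are considered here, and "the series" means these few. Any claim that something is new, unique, unknown or untested is made for them only; others in the source may bear on it.

Working notes on the aminated core series in a functional assay on MV4-11 cells (Homo sapiens) for inhibition, with a stated time of 120 h; on this read-out higher numbers stand for weaker inhibition and lower numbers for stronger inhibition.

Compound 1 `Cc1n[nH]c2ccc(-c3nc4cnc(N5CCN(C)CC5)cn4c3Nc3ccc(Cl)cc3)cc12` carries a chloro group on the aniline ring and gives 3510 nM in this assay. Going by the values given here, compound 2 `Cc1n[nH]c2ccc(-c3nc4cnc(N5CCN(C)CC5)cn4c3Nc3ccc(Br)cc3)cc12` bears bromo in place of chloro on that aromatic carbon and gives 2600 nM; the step of a 1.4-fold lower number from compound 1 to compound 2 (0.13 log units; within the scatter) is the only change within the set that has been measured at both ends, and it stays within the scatter, so exchanging the two halogens on this ring is not resolved by this assay.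

Compound 3 `Cc1ccc(C)c(Nc2c(-c3ccc4[nH]nc(C)c4c3)nc3cnc(N4CCN(C)CC4)cn23)c1` has a 2,5-dimethylphenyl group on the same nitrogen, but in this assay compound 3 is recorded as "not determined" (no result reported), so compound 3 has no value to stand on here and supplies no anchor for comparison.

Compound 4 `Cc1n[nH]c2ccc(-c3nc4cnc(N5CCN(C)CC5)cn4c3Nc3ccc(Br)cc3Cl)cc12` is reached from compound 3 by the change (4-bromo-2-chlorophenyl in place of 2,5-dimethylphenyl on a nitrogen on an aromatic ring). No measured step bears directly on this change; the single step shown, from compound 1 to compound 2, concerns a halogen exchange alone and gives no information on replacing two methyl groups by bromo and chloro. Compound 4 shares its bromo group with compound 2, whose value in this assay is the nearest reference.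

On that basis the number for compound 4 in this assay is expected to lie near the values of compound 1 and compound 2, estimated at 2500 nM with a range from 800 nM to 8000 nM, and no change beyond the scatter is anticipated from the additional chloro group.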

Compound 4, half-maximal inhibitory concentration: 9220 nM
The estimate for compound 4 lay 3.7-fold (0.57 log units) below the measured number; the measured number lies above the stated range.
By their numbers in this assay, from the lowest: compounds 2 and 1 (each within the scatter of the next); then compound 4.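

In this assay, the aniline ring proves sensitive to a second halogen in a way the exchange of one halogen for another could not show: chloro in place of hydrogen on an aromatic carbon gives a 3.5-fold higher number from compound 2 to compound 4 (0.55 log units; beyond the scatter) and so moves the number beyond the scatter, towards weaker inhibition. The change from 4-chlorophenyl to 4-bromo-2-chlorophenyl on the same nitrogen points the same way, with a 2.6-fold higher number from compound 1 to compound 4 (0.42 log units; beyond the scatter) as a second modest step, which leaves compound 4 as the weakest of the three compounds with numbers. Nothing available here bears on the reason for this shift.

As far as these compounds go, whether a fluoro, a methoxy or an amino group in place of that chloro would raise the number in the same way remains open, as does whether the chloro group would have the same effect with a group other than bromo on the ring. The change from 2,5-dimethylphenyl to 4-bromo-2-chlorophenyl cannot be read, since compound 3 has no single number in this assay to set against compound 4.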